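Swapping Isopropyl for Bromo on the Aromatic Ring

The compounds below may be only part of what the source reports. "The series", "measured", "known", "first", "only" and "open" are said of these compounds alone.

Of the compounds shown here, three sharing one core have been tested in an in vitro assay on 293-EBNA cells for binding affinity to corticotropin-releasing factor receptor 1 (Homo sapiens); a higher number here means a weaker inhibitor, a lower number a stronger inhibitor. Compound 1 `CCCC(CCC)Nc1nc(C)nc2c1nnn2-c1ccc(Br)cc1Br` gives 0.8 nM. Compound 2 `CCCCN(CC)c1nc(C)nc2c1nnn2-c1ccc(C(C)C)cc1Br` gives 7.5 nM, and compound 3 `COCC(C)(C)Nc1nc(C)nc2c1nnn2-c1ccc(C(C)C)cc1Br` gives 195 nM. Among these three numbers compound 2 stands second highest: compound 1 lies well below it, compound 3 well above it. Among the compounds with values here, the only measured step that changes a single site runs from compound 2 to compound 3, where a new amine produced a 26-fold higher number from compound 2 to compound 3 (1.41 log units; beyond the scatter); that step concerns the amine side of the molecule and tells nothing about the aromatic ring on the other side.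

Compound 4 `CCCCN(CC)c1nc(C)nc2c1nnn2-c1ccc(Br)cc1Br` keeps the amine of compound 2 and alters the ring: bromo in place of isopropyl on an aromatic carbon. Compound 1 carries the same pair of bromo groups on its ring, yet it also bears a different amine, so the gap between compound 1 and compound 2 cannot be credited to the ring alone. Within the data shown here, no measured step therefore bears directly on this change. Since both ring patterns occur in compounds with low numbers, compound 4 is expected to remain near compound 2, with an estimated step of a 1.5-fold lower number from compound 2 to compound 4 (0.18 log units; within the scatter) in this assay. Compound 4 is estimated at 5 nM, within a range from 1.5 nM to 15 nM.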

Compound 4, inhibition constant: 20.4 nM
Compound 4: middle estimate off by 4.1-fold (0.61 log units), on the low side, and the stated range ends below it.
By their numbers in this assay, from the lowest: compound 1; then compound 2; then compound 4; then compound 3.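

On the ring carbon para to a large group and meta to a bromo group, isopropyl now has its first direct comparison with bromo: with the butyl(ethyl)amino group held constant, this assay shows a 2.7-fold higher number from compound 2 to compound 4 (0.43 log units; beyond the scatter). So, with this amine, the isopropyl compound has the lower number, a modest step but one that lies beyond the scatter. With the two bromo groups held constant, the amine can also be read on its own, and replacing (1-propylbutyl)amino with butyl(ethyl)amino gives a 26-fold higher number from compound 1 to compound 4 (1.41 log units; beyond the scatter), a large step that shows the low number of compound 1 cannot be credited to its ring pattern alone; nothing available here explains why either change moves the number as it does.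

The compounds shown leave open whether the step between isopropyl and bromo keeps its direction and size alongside (1-propylbutyl)amino or (1-(methoxymethyl)-1-methylethyl)amino, since each of those amines appears here with only one of the two ring patterns. They also leave open how a chloro group, a methoxy group or a longer chain such as butyl would compare with isopropyl and bromo on this same ring carbon.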